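The source may report more compounds than this note shows. Statements on the series, on what has been measured and on what is new or still open speak of the compounds shown alone.

The three measured compounds share one core and differ only on a six-membered aromatic ring of carbon only that hangs from it. Compound 1 `Cc1nn(C)c2c1C(c1cccc(Cl)c1)=NCCN2` carries a chloro group on that ring, and in a functional assay on the whole organism for positive allosteric modulation, with Rattus norvegicus as the target (on this read-out higher numbers stand for an effect only at larger amounts of compound and lower numbers for an effect already at smaller amounts), compound 1 gives 0.63 mg/kg. Compound 2 `Cc1nn(C)c2c1C(c1cccc(Cl)c1C)=NCCN2` differs from compound 1 by methyl in place of hydrogen on an aromatic carbon and in this assay compound 2 gives 1.25 mg/kg; the step of a 2.0-fold higher number from compound 1 to compound 2 (0.30 log units; within the scatter) stays within the usual scatter. Compound 3 `Cc1cccc(C2=NCCNc3c2c(C)nn3C)c1` differs from compound 1 by methyl in place of chloro on an aromatic carbon; in this assay compound 3 gives 2.5 mg/kg, and the step of a 4.0-fold higher number from compound 1 to compound 3 (0.60 log units; beyond the scatter) is a modest one.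

Compound 4 `Cc1cc(C)cc(C2=NCCNc3c2c(C)nn3C)c1` has not yet been measured. It differs from compound 3 by methyl in place of hydrogen on an aromatic carbon. For the measured compounds named here, this is the same kind of change as the one from compound 1 to compound 2, but not the same change: in compound 2 the entering group sits ortho to a chloro group and ortho to a large group, while in compound 4 it sits meta to a large group and meta to a methyl group, and the two starting compounds themselves differ in the way already described.

Going by the values given here, with only one earlier example of this kind of change to go on, compound 4 is expected to move by about a 2.0-fold higher number from compound 3 to compound 4 (0.30 log units; within the scatter) from compound 3 in this assay, because the matching change gave a 2.0-fold higher number from compound 1 to compound 2 (0.30 log units; within the scatter). In this assay compound 4 is therefore estimated at about 5 mg/kg, most likely between 2.5 mg/kg and 10 mg/kg.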

Compound 4, minimum effective dose: > 10 mg/kg
Compound 4: a limit, no number; the forecaster's own chance of this, stated with the estimate: 10%; middle value at least 2.0-fold (0.30 log units) from the limit.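

In this assay, methyl in place of hydrogen on an aromatic carbon gives an at least 4.0-fold higher number from compound 3 to compound 4 (0.60 log units; beyond the scatter), so on the ring of compound 3 this small addition produces a shift beyond the usual scatter, while the earlier example stayed within it. Compound 4 gives > 10 mg/kg, which is a limit of the assay and not a number, so the size of this step is known only from one side. The result warns against assuming that the change carries over unaltered, yet it does not prove a difference, and with just one pair on each side, where the entering methyl also sits in a different place and the starting compounds carry different groups, no rule can be drawn: the same change on two cores in this assay, a 2.0-fold higher number (0.30 log units; within the scatter) from compound 1 to compound 2 and an at least 4.0-fold higher number (0.60 log units; beyond the scatter) from compound 3 to compound 4; the limit leaves it open whether they differ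

The compounds shown leave open whether the outcome follows the place of the entering methyl or the group already on the ring, a question that a chloro-bearing ring with the methyl in the place it holds in compound 4 would address. They also leave open how other groups at that place would behave, such as a methoxy group, a fluoro group, an amine or a carboxylic acid.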